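Methoxyphenyl to Methoxypyridinyl at the Chain Carbon

The source may report more compounds than this note shows. Statements on the series, on what has been measured and on what is new or still open speak of the compounds shown alone.

In a functional assay on NCI-H460 cells (Homo sapiens) for antiproliferative activity, with a stated time of 72 h (on this read-out lower numbers stand for stronger inhibition and higher numbers for weaker inhibition), compound 3 `C=CC[C@H]1C[C@]2([C@@H](C)Cc3cccc(OC)c3)OCOC2=CC1=O` gives 10600 nM, the highest of the numbers shown. Compound 1 `C=CC[C@H]1C[C@]2([C@@H](C)Cc3ccc(OC)c(OC)c3)OCOC2=CC1=O` gives 260 nM in this assay. Compound 2 `C=CC[C@@H]1C[C@]2([C@H](C)Cc3ccc(OC)c(OC)c3)OCOC2=CC1=O` gives only a limit in this assay, > 4000 nM. The step of a 41-fold higher number from compound 1 to compound 3 (1.61 log units; beyond the scatter) is large, as is an at least 15-fold higher number from compound 1 to compound 2 (1.18 log units; beyond the scatter). Compound 4 `C=CC[C@H]1C[C@]2([C@@H](C)Cc3ccc(OC)nc3)OCOC2=CC1=O` differs from compound 3 by 6-methoxypyridin-3-yl in place of 3-methoxyphenyl on a saturated chain carbon, two bonds along the chain from a saturated ring carbon. Among the compounds with values here, neither measured step places a nitrogen in the aromatic ring: one removes a methoxy group, the other changes only the configuration as drawn, so no measured step bears directly on this change. In this assay compound 4 is therefore expected to give 10000 nM, in the range 3000 nM to 35000 nM, an estimated step of a 1.1-fold lower number from compound 3 to compound 4 (0.03 log units; within the scatter) that would stay within the scatter.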

Compound 4, half-maximal inhibitory concentration: 330 nM
Compound 4: the middle estimate sits 30-fold (1.48 log units) above what was measured; measured number below the stated range.
By their numbers in this assay, from the lowest: compounds 1 and 4 (each within the scatter of the next); then compound 3.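

The change to 6-methoxypyridin-3-yl on this saturated chain carbon gives a 32-fold lower number from compound 3 to compound 4 (1.51 log units; beyond the scatter) in this assay, so a single methoxy group on the aromatic ring can go with a low number here, which compound 3 did not show. Compound 4 gives 330 nM and compound 1 gives 260 nM, values within the scatter of each other. Nothing given here accounts for this step. The compounds shown leave open how much of the step belongs to the ring nitrogen and how much to where the methoxy group sits. On these data alone, how an amine or a longer ether chain in place of that methoxy group would read in this assay also stays open.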